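The source may report more compounds than this note shows. Statements on the series, on what has been measured and on what is new or still open speak of the compounds shown alone.

In an ADME assay on MT4 cells (Homo sapiens) for cytotoxicity, read by MTT assay, with a stated time of 5 days (on this read-out lower numbers stand for higher toxicity in this test and higher numbers for lower toxicity in this test), three compounds built on a shared core have been examined, and a fourth is still to be tested. Compound 1, `Cc1cc(C)c(Oc2cc(Nc3ccc(C#N)cc3)ncc2C(=O)NCc2cn(Cc3ccccc3F)nn2)c(C)c1`, gives > 222000 nM, which is a limit of the test rather than a number. Compound 2, `Cc1cc(C)c(Oc2cc(Nc3ccc(C#N)cc3)ncc2C(=O)NCc2cn(Cc3ccccc3Cl)nn2)c(C)c1`, gives >= 188000 nM, again only a limit. Compound 3, `Cc1cc(C)c(Oc2cc(Nc3ccc(C#N)cc3)ncc2C(=O)NCc2cn(Cc3cccc(F)c3)nn2)c(C)c1`, gives >= 204000 nM, also a limit. Going by the values given here, compound 3 thus stands at a limit, as do the other two values shown, so no compound can be placed above or below another.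

Compound 4, `Cc1cc(C)c(Oc2cc(Nc3ccc(C#N)cc3)ncc2C(=O)NCc2cn(Cc3cccc(C#N)c3)nn2)c(C)c1`, differs from compound 3 in one place: cyano in place of fluoro on an aromatic carbon. The measured steps that touch this part of the molecule are a step that the two limits leave unreadable from compound 1 to compound 3, a step that the two limits leave unreadable from compound 2 to compound 3 and a step that the two limits leave unreadable from compound 1 to compound 2, each of them unreadable, as the values on both sides are limits: the limit of > 222000 nM in this assay, at which 1 of the 3 values shown sits, the limit of >= 188000 nM in this assay, at which 1 of the 3 values shown sits, and (the limit of >= 204000 nM in this assay, at which 1 of the 3 values shown sits). They give no size and no direction for the change to a nitrile, yet three different groups at this place have all left the toxicity too weak to register.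

Compound 4 is therefore expected to give 200000 nM in this assay, with a range from 100000 nM to 400000 nM. The expected step, an at least 1.0-fold lower number from compound 3 to compound 4 (0.00 log units; that floor lies within the scatter), is thus no change beyond the scatter, and most likely only a limit will be reported again.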

Compound 4, half-maximal cytotoxic concentration: >= 129000 nM
Compound 4: a limit, no number; the forecaster's own chance of this, stated with the estimate: 85%; the middle value lies beyond the limit too.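

In this assay compound 4 gives only a limit, as do compound 1, compound 2 and compound 3, so none of the steps from these three compounds to compound 4 can be read. The compounds shown leave open whether changing the group on this benzyl ring alters the half-maximal cytotoxic concentration at all, and in which direction.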